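This account rests on a few compounds, and the source may have more. Where it says the series, first, only, none or still open, it means among the compounds named here.

Compound 1 `COc1ccc(C(=O)/C=C/c2cc3ccccc3[nH]c2=O)cc1`: > 100000 nM.
Compound 2 `O=C(/C=C/c1cc2ccccc2[nH]c1=O)c1ccc(O)cc1`: 6360 nM.

In an ADME assay on NCI-H522 cells (Homo sapiens) for cytotoxicity, read by sulforhodamine B assay, with a stated time of 24 h (a higher number here means that more compound is tolerated, a lower number that less compound is tolerated), compound 2 gives 6360 nM, the only number shown. For compound 1 the value > 100000 nM is a limit of this assay (the limit of > 100000 nM in this assay, at which 1 of the 2 values shown sits). Compound 3 `O=C(/C=C/c1cc2ccccc2[nH]c1=O)c1ccc(Cl)cc1` differs from compound 2 by chloro in place of hydroxy on an aromatic carbon. Among the compounds with values here, the one measured step bearing on it, an at least 15-fold lower number from compound 1 to compound 2 (1.19 log units; beyond the scatter), shows that removing the hydroxy hydrogen raised the number sharply; since chloro removes the hydroxy entirely, a step up from compound 2 to compound 3 is expected, a 6.3-fold higher number from compound 2 to compound 3 (0.80 log units; beyond the scatter). Compound 3 is therefore estimated at 40000 nM, between 8000 nM and 100000 nM.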

Compound 3, concentration lethal to 50% of the cells: 47200 nM
For compound 3 the middle estimate is 1.2-fold (0.07 log units) below the measured one; the range from low to high includes it.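

In this assay, chloro in place of hydroxy gives a 7.4-fold higher number from compound 2 to compound 3 (0.87 log units; beyond the scatter), so the low number of compound 2 is not kept when another group of one heavy atom stands at this place. Chloro and methoxy also differ, with an at least 2.1-fold lower number from compound 1 to compound 3 (0.32 log units; beyond the scatter), which leaves compound 2 with the lowest number of the three. The value of compound 1 is a limit of this assay: the limit of > 100000 nM in this assay, at which 1 of the 3 values shown sits.

As far as these compounds go, it remains open whether an amine or a carboxylic acid at this place would give a number nearer that of compound 2 or that of compound 3.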